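Swapping Nitro for Methylsulfanyl on a Hydrazone Series

The source may hold more compounds than are shown below. What is called first, only, known or untested is meant among the compounds shown, and "the series" means these compounds.

Measured compounds:
- compound 1 `O=C(COc1cccc2ccccc12)N/N=C/c1ccc([N+](=O)[O-])cc1`: 14.2 ug/mL
- compound 2 `C/C(=N\NC(=O)COc1cccc2ccccc12)c1ccc(O)cc1`: 11.1 ug/mL
- compound 3 `C/C(=N\NC(=O)COc1cccc2ccccc12)c1cccc([N+](=O)[O-])c1`: 10.5 ug/mL

In an ADME assay on HEL cells (Homo sapiens) for cytotoxicity (on this read-out higher numbers stand for lower toxicity in this test and lower numbers for higher toxicity in this test), compound 1 gives 14.2 ug/mL. Its nearest neighbour is compound 2, and the gap between the two is within the scatter; the furthest is compound 3, and that gap is also within the scatter. All three numbers are therefore indistinguishable on this read-out.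

Compound 4 `CSc1ccc(/C=N/NC(=O)COc2cccc3ccccc23)cc1` has not yet been measured. It differs from compound 1 in one place: methylsulfanyl in place of nitro on an aromatic carbon

Going by the values given here, only one step between measured compounds is available, a 1.1-fold lower number from compound 2 to compound 3 (0.02 log units; within the scatter), and it concerns a different pair of groups, so it bears on the new change only loosely. Among the compounds with values here, it showed no movement beyond the scatter, and no measured pair gives any sign that the nature of the group on this aromatic carbon shifts the number. The expected step of a 1.1-fold lower number from compound 1 to compound 4 (0.04 log units; within the scatter) is therefore none beyond the scatter. Compound 4 is expected to give about 13 ug/mL, within 7 ug/mL to 26 ug/mL.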

Compound 4, half-maximal cytotoxic concentration: > 100 ug/mL
Compound 4 was reported as a limit; the forecaster's own chance of this, stated with the estimate: 10%; middle value at least 7.6-fold (0.88 log units) away from the limit.
By their numbers in this assay, from the lowest: compounds 3, 2 and 1 (each within the scatter of the next). At a limit, above all of these: compound 4.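

On this aromatic carbon, para to a large group, methylsulfanyl in place of nitro gives an at least 7.0-fold higher number from compound 1 to compound 4 (0.84 log units; beyond the scatter) in this assay, the first step among these compounds to lie beyond the scatter. The reading for compound 4 is a limit of the assay and not a number, the only such reading shown: the limit of > 100 ug/mL in this assay, at which 1 of the 4 values shown sits. So the group at this position can matter in this test, with compound 4 the less toxic of the pair, although the one earlier step, on a different pair of groups, stayed within the scatter.

With the core of compound 1, only nitro and methylsulfanyl are shown on this carbon, so it stays open whether an amine or a methoxy group there would read like compound 1 or like compound 4. Going by these compounds, whether the same swap would move the number in compound 3 also stays open.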